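Removing the ring methyl: solubility of compound 4

This account rests on a few compounds, and the source may have more. Where it says the series, first, only, none or still open, it means among the compounds named here.

Measured compounds in a physicochemical assay (Homo sapiens) for solubility, with a stated time of 18 h, at pH 7.4; a lower number here means a less soluble compound, a higher number a more soluble compound:
- compound 1, `CN1CCN(c2ccc(/C=C3/SC(Nc4ccc(O)cc4)=NC3=O)cc2)CC1`, gives 0.01 ug/mL
- compound 2, `O=C1N=C(Nc2ccc(O)cc2)S/C1=C/c1ccc(N2CCNCC2)cc1`, gives 13.9 ug/mL
- compound 3, `CN1CCN(c2ccc(/C=C3/SC(Nc4ccc(Oc5ccccc5)cc4)=NC3=O)cc2)CC1`, gives 0.1 ug/mL

Compound 1 and compound 2 share a core and differ in one place: hydrogen in place of methyl on an amine nitrogen in a ring. This change gave the step of a 1400-fold higher number from compound 1 to compound 2 (3.14 log units; beyond the scatter) in this assay.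

Compound 3 carries a different core, and the difference from compound 1 is phenyl in place of hydrogen on an oxygen on an aromatic ring. That change gave the step of a 10-fold higher number from compound 1 to compound 3 (1.00 log units; beyond the scatter) in this assay, so compound 3 stands second highest of the three measured numbers.

Compound 4, `O=C1N=C(Nc2ccc(Oc3ccccc3)cc2)S/C1=C/c1ccc(N2CCNCC2)cc1`, has not yet been measured in this assay. It differs from compound 3 by hydrogen in place of methyl on an amine nitrogen in a ring. This is the same change that carried compound 1 to compound 2, made here on the core of compound 3, and the place where the methyl leaves is the same in both pairs.

Within the data shown here, because the earlier step of a 1400-fold higher number from compound 1 to compound 2 (3.14 log units; beyond the scatter) was large and lay far beyond the scatter, compound 4 is expected to show a large rise in this assay as well, but the core of compound 3 is the one with the phenoxy group and only one example of the change is available, so the expected step of a 150-fold higher number from compound 3 to compound 4 (2.18 log units; beyond the scatter) is kept smaller than the earlier one. Compound 4 is therefore estimated at 15 ug/mL, with a plausible span from 1.5 ug/mL to 150 ug/mL.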

Compound 4, solubility: 0.1 ug/mL
Compound 4: middle estimate off by 150-fold (2.18 log units), on the high side, outside the stated range (below it).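

In this assay, replacing methyl with hydrogen on the ring nitrogen, the change from 4-methylpiperazin-1-yl to piperazin-1-yl, gave a 1400-fold higher number from compound 1 to compound 2 (3.14 log units; beyond the scatter) on one core, but on the core of compound 3 it gave no change at the digits printed from compound 3 to compound 4 (within the scatter), so the large step did not transfer. The phenyl on the oxygen also behaved differently in the two settings, giving a 10-fold higher number from compound 1 to compound 3 (1.00 log units; beyond the scatter) when the ring nitrogen carried methyl and a 140-fold lower number from compound 2 to compound 4 (2.14 log units; beyond the scatter) when it carried hydrogen, which shows that the effect of each change in this small set depends on the other. This does not show which result is typical of the series, as each comparison rests on a single pair of compounds, and no measurement shown here explains the difference between the two cores.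

The compounds shown leave open whether the large step would return with a methyl group or a longer alkyl chain on that oxygen in place of phenyl. They also leave open how the series would respond to an acetyl group or a carboxylic acid on the ring nitrogen, in either core.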